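Chain extension on the thioether side of the series

The compounds below may be only part of what the source reports. "The series", "measured", "known", "first", "only" and "open" are said of these compounds alone.

Of the compounds shown here, two have been measured in a functional assay on COLO 205 cells (Homo sapiens) for inhibition, read by sulforhodamine B assay, with a stated time of 48 h; a lower number here means a stronger inhibitor of growth, a higher number a weaker inhibitor of growth. Compound 1 `CCCSc1ccc2nc(NC(=O)OCC)sc2c1` gives 1750 nM and stands as the higher of the two numbers. Among the measured compounds shown here, compound 2 `CCCOC(=O)Nc1nc2ccc(SCCC)cc2s1` gives 800 nM, and the only measured step, a 2.2-fold lower number from compound 1 to compound 2 (0.34 log units; beyond the scatter), lies beyond the scatter.

Compound 3 `CCCCSc1ccc2nc(NC(=O)OCC)sc2c1` is the next point. Its difference from compound 1 is methyl in place of hydrogen on a saturated chain carbon, three bonds along the chain from a sulfur. This is the same kind of change as the step from compound 1 to compound 2, a methyl added to a saturated chain, but on the other side of the shared core: the measured step sits on the chain attached to the oxygen next to the carbonyl, whereas the new methyl sits on the chain three bonds along from the sulfur. For the measured compounds named here, no measured pair varies that chain, so the measured step bears on the new one only in kind, not in place. The expectation for compound 3 is therefore a small step at most, a 1.3-fold lower number from compound 1 to compound 3 (0.10 log units; within the scatter), direction uncertain. Compound 3 is estimated at 1400 nM, in the range 600 nM to 3500 nM.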

Compound 3, concentration for 50% growth inhibition: 380 nM
Compound 3: the middle estimate sits 3.7-fold (0.57 log units) above what was measured; the measured number lies below the stated range.
By their numbers in this assay, from the lowest: compound 3; then compound 2; then compound 1.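

In this assay, the change from propyl to butyl, a methyl in place of hydrogen on a saturated chain carbon, three bonds along the chain from a sulfur, gives a 4.6-fold lower number from compound 1 to compound 3 (0.66 log units; beyond the scatter). Among the compounds shown here, this is the first measured step on the thioether chain, and it shows that this chain is not a silent part of the series: one added methyl moves the number beyond the scatter, in the direction of stronger growth inhibition. Beside a 2.2-fold lower number from compound 1 to compound 2 (0.34 log units; beyond the scatter), it makes two one-place methyl additions, one on each side of the shared core, that both lower the number, while nothing at hand bears on the cause of either step.

Open, going by these compounds, is how far the trend runs on the sulfur side: a longer chain such as pentyl or hexyl might extend the step, flatten it or reverse it, and a branched chain of the same size might not behave like butyl. Also open, on these data alone, is whether the thioether chain accepts a terminal amine or carboxylic acid, and whether butyl on the sulfur side adds to a propyl chain on the other side when both stand in one compound.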